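A few compounds are considered here, and "the series" means these few. Any claim that something is new, unique, unknown or untested is made for them only; others in the source may bear on it.

Measured in an ADME assay on RAW264.7 cells (Mus musculus) for cytotoxicity, read by MTT assay, with a stated time of 24 h; on this read-out higher numbers stand for lower toxicity in this test and lower numbers for higher toxicity in this test:
- compound 1 `CC/C=C\C[C@H]1C(=O)C=C[C@H]1CC(=O)OCCCC`: 31 uM
- compound 2 `CC/C=C\C[C@H]1C(=O)C=C[C@H]1CC(=O)OCCCCC`: 37 uM
- compound 3 `CC/C=C\C[C@H]1C(=O)C=C[C@H]1CC(=O)OCCOCCO`: 166 uM

Compound 3 stands highest of the three, clear of the other two: a 5.4-fold higher number from compound 1 to compound 3 (0.73 log units; beyond the scatter) and a 4.5-fold higher number from compound 2 to compound 3 (0.65 log units; beyond the scatter). Those modest steps replaced ethyl or propyl with 2-hydroxyethoxy. Compound 4 `CC/C=C\C[C@H]1C(=O)C=C[C@H]1CC(=O)OCCOCCOCCOC` differs from compound 3 by one change: 2-methoxyethyl in place of hydrogen on an oxygen on a saturated carbon. This extends the chain of compound 3 and caps its hydroxy as 2-methoxyethoxy. For the measured compounds named here, the nearest precedent for simple extension is small: a 1.2-fold higher number from compound 1 to compound 2 (0.08 log units; within the scatter). The larger steps offer only weak support for a further rise. A small upward move within the scatter is therefore expected, a 1.1-fold higher number from compound 3 to compound 4 (0.06 log units; within the scatter). For compound 4 the estimated value is 190 uM, with an expected range of 90 uM to 400 uM.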

Compound 4, half-maximal toxic concentration: 163 uM
Estimate against measurement, compound 4: 1.2-fold (0.07 log units) above; measured number inside the range.
By their numbers in this assay, from the lowest: compounds 1 and 2 (each within the scatter of the next); then compounds 4 and 3 (each within the scatter of the next).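

Capping the hydroxy of compound 3 as 2-methoxyethoxy, on this oxygen on a saturated carbon, leaves the number in this assay unmoved (a 1.0-fold lower number from compound 3 to compound 4 (0.01 log units; within the scatter)), so the hydrogen on that oxygen is not needed to hold it. The longer chain keeps the whole rise over the simple alkyl chains (a 4.4-fold higher number from compound 2 to compound 4 (0.64 log units; beyond the scatter); a 5.3-fold higher number from compound 1 to compound 4 (0.72 log units; beyond the scatter)). No evidence given here accounts for these numbers.

On these data alone, whether a terminal amine or carboxylic acid at this chain end, or a still longer chain of the same repeating kind, would hold the number remains open.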